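Thioether versus sulfone on the oxadiazole series

The source may hold more compounds than are shown below. What is called first, only, known or untested is meant among the compounds shown, and "the series" means these compounds.

Measured so far:
compound 1, `CC(O)(CSc1ccccc1)c1nc(-c2ccc(F)c(Cl)c2)no1`: 5500 nM
compound 2, `CC(O)(CS(=O)(=O)c1ccc(Cl)cc1)c1nc(-c2ccc([N+](=O)[O-])c(C(F)(F)F)c2)no1`: 91000 nM

In a functional assay on DU-145 cells (Homo sapiens) for cytotoxicity, read by MTT assay (on this read-out lower numbers stand for stronger inhibition and higher numbers for weaker inhibition), compound 1 gives 5500 nM and compound 2 gives 91000 nM. Compound 2 has the higher of the two numbers, and the gap to compound 1 is beyond the scatter. The two compounds differ in more than one place, so nothing in these numbers can be tied to a single group.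

Compound 3, `CC(O)(CSc1ccc(F)cc1)c1nc(-c2ccc([N+](=O)[O-])c(C(F)(F)F)c2)no1`, has not been measured in this assay. It differs from compound 2 by (4-fluorophenyl)sulfanyl in place of (4-chlorophenyl)sulfonyl on a saturated chain carbon, two bonds along the chain from an aromatic carbon and an oxygen on a saturated carbon, while keeping the aryl group of compound 2 on the shared core. Going by the values given here, the entering group resembles the sulfanyl present in compound 1, the only compound here with the lower number. Among the compounds with values here, with no single-point step recorded between the two measured compounds, the expectation can only be rough: a decrease beyond the scatter is expected, of size a 4.6-fold lower number from compound 2 to compound 3 (0.66 log units; beyond the scatter), because compound 1 gives 5500 nM with a sulfanyl linker. For compound 3 the estimate is 20000 nM, within 5000 nM to 80000 nM.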

Compound 3, half-maximal inhibitory concentration: 5100 nM
Estimate against measurement, compound 3: 3.9-fold (0.59 log units) above; the range from low to high includes it.
By their numbers in this assay, from the lowest: compounds 3 and 1 (each within the scatter of the next); then compound 2.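

With the aryl group of compound 2 kept on the shared core, replacing (4-chlorophenyl)sulfonyl with (4-fluorophenyl)sulfanyl on a saturated chain carbon gives an 18-fold lower number from compound 2 to compound 3 (1.25 log units; beyond the scatter) in this assay. Going by these compounds alone, this is the first single-place step, and it shows that the group at this position can shift the read-out by a large margin, which the first two compounds could not show with their several differences. The change is still a composite one, as the sulfonyl becomes a sulfanyl and the chlorine on the ring becomes a fluorine in the same step, and no measurement on hand bears on the reason for its size.

Still open, on these data alone, is how the step divides between the sulfur linker and the ring halogen; a (4-chlorophenyl)sulfanyl or a (4-fluorophenyl)sulfonyl at this place would separate the two. Also open, as far as these compounds go, is whether sulfur is needed at all in the linker, for which a sulfinyl, an ether oxygen or a methylene at the same place would be the next points of comparison.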